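The source may report more compounds than this note shows. Statements on the series, on what has been measured and on what is new or still open speak of the compounds shown alone.

Compound 1 `C=CCn1ncc2c(CC)ncn2c1=O` and compound 3 `C=CCn1ncc2c(CCC)ncn2c1=O` share one core, while compound 2 `CCc1nc(C)c2cnn(CC)c(=O)n12` rests on another; the difference between the two cores is not broken down here. In a functional assay for inhibition, with Homo sapiens as the target (on this read-out higher numbers stand for weaker inhibition and lower numbers for stronger inhibition), compound 1 gives > 48000 nM, which is a limit of the assay and not a number. In this assay compound 3 gives > 48000 nM, again a limit. The change leading from compound 1 to compound 3, (methyl in place of hydrogen on a saturated chain carbon, two bonds along the chain from an aromatic carbon), makes a step that reads a step that the two limits leave unreadable from compound 1 to compound 3. In this assay, among the compounds with values here, compound 2 gives 75600 nM, the only number among the three values shown. Compound 4 `CCn1ncc2c(C)nc(C(C)C)n2c1=O` is not yet measured; it arises from compound 2 by methyl in place of hydrogen on a saturated chain carbon bound to an aromatic carbon and a saturated chain carbon, the same kind of change as from compound 1 to compound 3, though here the carbon taking the methyl is bound to an aromatic carbon and a saturated chain carbon rather than two bonds along the chain from an aromatic carbon. Because (the limit of > 48000 nM in this assay, at which 2 of the 3 values shown sit), two of the three values give no size to compare against. Within the data shown here, the step from compound 2 to compound 4 is expected at a 1.3-fold lower number from compound 2 to compound 4 (0.10 log units; within the scatter), resting on compound 2 at 75600 nM as the only number available. Compound 4 is therefore estimated in this assay at 60000 nM, between 20000 nM and 180000 nM, with a real chance that only a limit is reported.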

Compound 4, half-maximal inhibitory concentration: > 48000 nM
Compound 4 was reported as a limit; the forecaster's own chance of this, stated with the estimate: 50%; the middle value is on the limit's open side.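

In this assay compound 4 gives > 48000 nM as a limit of the assay and not a number. No size can therefore be read for the step from compound 2 to compound 4. The compounds shown leave open how far either chain change moves inhibition, because the values rest largely on one limit: the limit of > 48000 nM in this assay, at which 3 of the 4 values shown sit.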